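Swapping a fluorinated aryl ring for a methoxylated one

This account rests on a few compounds, and the source may have more. Where it says the series, first, only, none or still open, it means among the compounds named here.

compound 1 `O=C(NCCCCc1ccccc1)n1cc(-c2ccccc2)oc1=O`: 90 nM
compound 2 `O=C(NCCCCc1ccccc1)n1cc(-c2ccc(F)cc2)oc1=O`: 185 nM

In an assay on isolated protein for inhibition of acid ceramidase (Homo sapiens), read by LC-MS, with a stated time of 1 h (on this read-out higher numbers stand for weaker inhibition and lower numbers for stronger inhibition), compound 1 gives 90 nM, and compound 2 gives 185 nM. Compound 2 thus stands highest of the two numbers; its nearest neighbour is compound 1, separated by a 2.1-fold higher number from compound 1 to compound 2 (0.31 log units; beyond the scatter). Compound 3 `COc1cccc(-c2cn(C(=O)NCCCCc3ccccc3)c(=O)o2)c1` differs from compound 2 in 3-methoxyphenyl in place of 4-fluorophenyl on an aromatic carbon. Among the compounds with values here, the only measured step that bears on this change is a 2.1-fold higher number from compound 1 to compound 2 (0.31 log units; beyond the scatter), which shows that a substituent change on this aryl ring moved the read-out only modestly. Within the data shown here, no measured compound carries a methoxy group, so the direction of the new change has no anchor in the data. Compound 3 is therefore expected to shift by a 1.2-fold lower number from compound 2 to compound 3 (0.09 log units; within the scatter), a change not clearly beyond the scatter. The estimate for compound 3 is 150 nM, ranging from 50 nM to 500 nM.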

Compound 3, half-maximal inhibitory concentration: 341 nM
Estimate against measurement, compound 3: 2.3-fold (0.36 log units) below, and the stated range covers the measured number.
By their numbers in this assay, from the lowest: compound 1; then compounds 2 and 3 (each within the scatter of the next).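

In this assay, 3-methoxyphenyl in place of 4-fluorophenyl gives a 1.8-fold higher number from compound 2 to compound 3 (0.27 log units; within the scatter), so this position does not separate these two substituted rings, although the entering group carries a hydrogen-bond acceptor and the leaving group carries none. Methoxy in place of hydrogen gives a 3.8-fold higher number from compound 1 to compound 3 (0.58 log units; beyond the scatter), so among these compounds both substituted rings, in compound 2 and compound 3, give higher numbers than the plain phenyl ring of compound 1, and none goes against this. Nothing available accounts for this result.

Compound 2 and compound 3 differ in both the group and its place on the ring, so the effects of the two remain unseparated. Going by these compounds, whether an amine or a carboxylic acid on this aryl ring would give a number lower than that of compound 1 remains open.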